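Swapping the pyrrolidin-1-yl group of compound 2

The source may hold more compounds than are shown below. What is called first, only, known or untested is meant among the compounds shown, and "the series" means these compounds.

In a functional assay on KYSE-450 cells (Homo sapiens) for inhibition, read by CCK-8 assay, with a stated time of 48 h (on this read-out lower numbers stand for stronger inhibition and higher numbers for weaker inhibition), compound 1 (`COc1ccc(CN(C(=O)CSC(=S)N2CCN(C(C)=O)CC2)c2cc(OC)c(OC)c(OC)c2)cc1`) gives 370 nM, while compound 2 (`COc1ccc(CN(C(=O)CSC(=S)N2CCCC2)c2cc(OC)c(OC)c(OC)c2)cc1`) gives 13800 nM, the higher of the two numbers and so the weaker inhibition. Among the measured compounds shown here, only one measured step bears on what comes next: a 37-fold higher number from compound 1 to compound 2 (1.57 log units; beyond the scatter), which puts pyrrolidin-1-yl in place of 4-acetylpiperazin-1-yl on a thiocarbonyl carbon. That step is large and beyond the scatter, so this place clearly matters in these two compounds. Compound 3 (`COc1ccc(CN(C(=O)CSC(=S)N2CCc3cc(Br)ccc32)c2cc(OC)c(OC)c(OC)c2)cc1`) changes the same place: 5-bromo-2,3-dihydro-1H-indol-1-yl in place of pyrrolidin-1-yl on a thiocarbonyl carbon. This new group has not been tested, so one step gives only a rough guide. With compound 2 at the weak end at 13800 nM, a moderate improvement seems the likelier outcome, smaller than the measured step. The expected change is a 6.9-fold lower number from compound 2 to compound 3 (0.84 log units; beyond the scatter) in this assay. For compound 3 the estimated value is 2000 nM, with an expected range from 400 nM to 10000 nM.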

Compound 3, half-maximal inhibitory concentration: > 20000 nM
Compound 3 gave a limit, no number; the forecaster's own chance of this, stated with the estimate: 5%; at least 10-fold (1.00 log units) between middle value and limit.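

In this assay compound 3 gives no number but a limit, > 20000 nM: the limit of > 20000 nM in this assay, at which 1 of the 3 values shown sits. Going from the pyrrolidin-1-yl group to the larger 5-bromo-2,3-dihydro-1H-indol-1-yl group gives an at least 1.4-fold higher number from compound 2 to compound 3 (0.16 log units; that floor lies within the scatter), so this larger group, with its six-membered aromatic ring of carbon only, brings no sign of a gain, though a real loss cannot be claimed from that floor. Against the 4-acetylpiperazin-1-yl group the gap is an at least 54-fold higher number from compound 1 to compound 3 (1.73 log units; beyond the scatter), so on this thiocarbonyl carbon a larger group alone does not restore strong inhibition, and the 4-acetylpiperazin-1-yl group keeps its clear lead.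

Still open, on these data alone, is whether that lead rests on the acetyl group or on the ring itself, which a plain piperazin-1-yl or a morpholin-4-yl group would test. As far as these compounds go, the part played by the bromine is also open, and the 2,3-dihydro-1H-indol-1-yl group without bromine would separate it from the aromatic ring.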